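A few compounds are considered here, and "the series" means these few. Any claim that something is new, unique, unknown or untested is made for them only; others in the source may bear on it.

Of the compounds shown here, three sharing one core have been measured in an assay on CHO cells for antagonist activity at transient receptor potential cation channel subfamily V member 1 (Homo sapiens), read by scintillation counting, with a stated time of 5 min, in the presence of a further agent that is not named here; on this read-out lower numbers stand for an effect already at smaller amounts and higher numbers for an effect only at larger amounts of compound. Compound 1 (`CN(C)C1(Cc2ccccc2)CCN(c2cc(C(F)(F)F)ccc2CNC(=O)Nc2ccc(CO)c(F)c2)CC1`) gives 81 nM, compound 2 (`CN(C)C1(Cc2ccccc2)CCN(c2cc(C(F)(F)F)ccc2CNC(=O)Nc2ccc3c(c2)OCC3)CC1`) gives 31.3 nM, and compound 3 (`CN(C)C1(Cc2ccccc2)CCN(c2cc(C(F)(F)F)ccc2CNC(=O)Nc2cccc3[nH]c(=O)ccc23)CC1`) gives 30.6 nM. Compound 3 thus carries the lowest number of the three, but its gap to compound 2 lies within the scatter, so the two cannot be told apart; only compound 1 stands clearly apart, with a 2.6-fold lower number from compound 1 to compound 3 (0.42 log units; beyond the scatter).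

Compound 4 (`CN(C)C1(Cc2ccccc2)CCN(c2cc(C(F)(F)F)ccc2CNC(=O)Nc2ccc3cccnc3c2)CC1`) follows from compound 3 by one change: a group of 10 heavy atoms (9 carbon, 1 nitrogen; one six-membered aromatic ring of carbon only, one six-membered aromatic ring with 1 hetero atom) in place of a group of 11 heavy atoms (9 carbon, 1 nitrogen, 1 oxygen; one six-membered aromatic ring of carbon only, one six-membered aromatic ring with 1 hetero atom), on an amide-type nitrogen. The step that bears most on it is the exchange of one bicyclic group for another between compound 2 and compound 3, which gave a 1.0-fold lower number from compound 2 to compound 3 (0.01 log units; within the scatter). The two earlier exchanges of this group, a 2.6-fold lower number from compound 1 to compound 2 (0.41 log units; beyond the scatter) and a 2.6-fold lower number from compound 1 to compound 3 (0.42 log units; beyond the scatter), were both modest. A step of similar or smaller size is therefore expected here, in no clear direction beyond the scatter; the expectation is a 1.2-fold higher number from compound 3 to compound 4 (0.09 log units; within the scatter). Compound 4 is estimated at 38 nM, with a likely range from 15 nM to 95 nM.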

Compound 4, half-maximal effective concentration: 42 nM
Estimate against measurement, compound 4: 1.1-fold (0.04 log units) below, and the stated range covers the measured number.
By their numbers in this assay, from the lowest: compounds 3, 2, 4 and 1 (each within the scatter of the next, the first and the last beyond it).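

In this assay, quinolin-7-yl on the amide-type nitrogen removes the one hydrogen-bond donor of the group it replaces, yet the result is a 1.4-fold higher number from compound 3 to compound 4 (0.14 log units; within the scatter) and, against the other bicyclic group, a 1.3-fold higher number from compound 2 to compound 4 (0.13 log units; within the scatter), so this change leaves the number within the scatter. The comparison with the monocyclic group gives a 1.9-fold lower number from compound 1 to compound 4 (0.29 log units; within the scatter) and is also within the scatter, so compound 4 cannot be told apart from compound 1, although compounds 2 and 3 can. No measured evidence here explains these small steps.

As far as these compounds go, whether this position stays as undemanding with a fully carbon naphthyl group remains open. So does the effect of adding an amine or a carboxylic acid to the quinolin-7-yl group.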